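The source may hold more compounds than are shown below. What is called first, only, known or untested is meant among the compounds shown, and "the series" means these compounds.

Among the compounds with values here, in a functional assay on MKN-45 cells (Homo sapiens) for cytotoxicity (on this read-out higher numbers stand for weaker inhibition and lower numbers for stronger inhibition), compound 2 `COC(=O)c1ccc(C(=O)Nc2cccc3c2N(S(=O)(=O)c2ccc(OC)cc2)CC3)cc1` gives 312 nM as the higher of the two numbers so far, while compound 1 `COc1ccc(S(=O)(=O)N2CCc3cccc(NC(=O)c4cccs4)c32)cc1` gives 31 nM as the lower. Compound 3 `COc1ccc(S(=O)(=O)N2CCc3cccc(NC(=O)Oc4ccccc4)c32)cc1` has phenoxy in place of 4-(methoxycarbonyl)phenyl on a carbonyl carbon. Within the data shown here, only one measured step bears on this place (a 10-fold higher number from compound 1 to compound 2 (1.00 log units; beyond the scatter)), and it is modest but beyond the scatter. Among the measured compounds shown here, no measured compound carries phenoxy, so compound 3 is expected to fall between the two known numbers, probably closer to compound 2. The estimated change is a 2.6-fold lower number from compound 2 to compound 3 (0.41 log units; beyond the scatter) toward a lower number. Compound 3 is estimated at 120 nM (range 30 nM to 500 nM).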

Compound 3, half-maximal inhibitory concentration: > 10000 nM
Compound 3: no number, only a limit; the forecaster's own chance of this, stated with the estimate: 2%; middle value at least 83-fold (1.92 log units) from the limit.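

For compound 3, this assay gives a limit and not a number: the limit of > 10000 nM in this assay, at which 1 of the 3 values shown sits.

Phenoxy on this carbonyl carbon gives an at least 32-fold higher number from compound 2 to compound 3 (1.50 log units; beyond the scatter) and, set against thiophen-2-yl, gives an at least 320-fold higher number from compound 1 to compound 3 (2.50 log units; beyond the scatter) as well. The earlier step between two groups at this place was modest, so this change shows that the same place can cost far more activity than those compounds revealed.

The compounds shown do not separate the effect of the linking oxygen from that of the phenyl ring it carries. A plain phenyl or a phenylamino group at this place would help tell them apart.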